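A few compounds are considered here, and "the series" means these few. Any claim that something is new, unique, unknown or untested is made for them only; others in the source may bear on it.

Of the compounds shown here, three have been tested in a functional assay on HT-29 cells (Homo sapiens) for cytotoxicity, read by MTT assay, with a stated time of 72 h (on this read-out lower numbers stand for higher toxicity in this test and higher numbers for lower toxicity in this test), and none of them has given a number. Compound 1 `C[Se]/C(=N\C(=O)c1cc2ccccc2s1)NC(=O)c1cc2ccccc2s1` sits at the limit of this assay, reported as > 100000 nM. Compound 2 `C[Se]/C(=N\C(=O)c1cccs1)NC(=O)c1cccs1` likewise stands at the limit, giving > 100000 nM. Compound 3 `O=C(/N=C(/NC(=O)c1cc(-c2ccccc2)nc2ccccc12)[Se]Cc1ccccc1)c1cc(-c2ccccc2)nc2ccccc12`, the larger analogue, is also reported only as a limit in this assay, at > 100000 nM. So compound 3 stands at the same point as the other two: the limit of > 100000 nM in this assay, at which 3 of the 3 values shown sit, and no ordering among compounds 1, 2 and 3 can be read from these figures.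

The next compound follows from compound 3 by one change. Compound 4 `C[Se]/C(=N\C(=O)c1cc(-c2ccccc2)nc2ccccc12)NC(=O)c1cc(-c2ccccc2)nc2ccccc12` differs from compound 3 in that (hydrogen in place of phenyl on a saturated chain carbon bound to a selenium atom); cut one bond further out, the same difference reads benzyl to methyl.

Because all three measured compounds sit at the limit of > 100000 nM in this assay, at which 3 of the 3 values shown sit, no step beyond the scatter is expected from compound 3 to compound 4, and the result is expected again to be a limit rather than a number. The estimate for compound 4 in this assay is 150000 nM, between 50000 nM and 500000 nM, which means an expected step that the limit leaves unreadable from compound 3 to compound 4.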

Compound 4, concentration lethal to 50% of the cells: 90700 nM
Compound 4: the middle estimate sits 1.7-fold (0.22 log units) above what was measured, within the range that was stated.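

In this assay, for the compounds shown here, compound 4 is the first of the series to give a number rather than a limit, at 90700 nM. With hydrogen in place of phenyl on a saturated chain carbon bound to a selenium atom, that is, benzyl to methyl, the data give an at least 1.1-fold lower number from compound 3 to compound 4 (0.04 log units; that floor lies within the scatter), so the change can be bounded from one side only and cannot be shown to move the number beyond the scatter. The other three compounds all remain at a limit of the assay: the limit of > 100000 nM in this assay, at which 3 of the 4 values shown sit.

Going by these compounds, the true size of this step stays open, since compound 3 offers only a limit as its starting point. Also open, on these data alone, is how an ethyl group or a longer chain would read at this place, or a benzyl group whose phenyl carries an amine or a carboxylic acid.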